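This account rests on a few compounds, and the source may have more. Where it says the series, first, only, none or still open, it means among the compounds named here.

Compound 1 `NS(=O)(=O)c1ccc(N2N=C(c3ccc(OCc4ccccc4)cc3)CC2c2ccccc2)cc1`: > 100000 nM
Compound 2 `Cc1ccc(C2CC(c3ccc(OCc4ccccc4)cc3)=NN2c2ccc(S(N)(=O)=O)cc2)cc1`: 100000 nM
Compound 3 `NS(=O)(=O)c1ccc(N2N=C(c3ccc(OCc4ccccc4)cc3)CC2c2ccccc2F)cc1`: > 100000 nM

In an ADME assay on Vero 76 cells (Chlorocebus sabaeus) for cytotoxicity, read by MTT assay, with a stated time of 96 h (a lower number here means that less compound is tolerated, a higher number that more compound is tolerated), compound 3 gives > 100000 nM, which is a limit and not a number. Compound 1 gives > 100000 nM, also a limit. Among the measured compounds shown here, compound 2 gives 100000 nM, the only exact value. Compound 4 `NS(=O)(=O)c1ccc(N2N=C(c3ccc(OCc4ccccc4)cc3)CC2c2cccc(Cl)c2)cc1` carries 3-chlorophenyl in place of 2-fluorophenyl on a saturated ring carbon.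

The nearest evidence is a step that the two limits leave unreadable from compound 1 to compound 3 and a number no lower from compound 2 to compound 3 (the limit leaves the size open), and neither size can be read. With a number no higher from compound 1 to compound 2 (the limit leaves the size open) there is likewise no measured size, so no step beyond the scatter is expected in this assay. The estimated step is a number no higher from compound 3 to compound 4 (the limit leaves the size open). For compound 4 the expected value is 100000 nM, with an estimated range of 45000 nM to 100000 nM.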

Compound 4, half-maximal cytotoxic concentration: 85000 nM
Compound 4: the middle estimate sits 1.2-fold (0.07 log units) above what was measured; the measured number falls inside the stated range.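

On the saturated ring carbon, 3-chlorophenyl gives in this assay an at least 1.1-fold lower number from compound 3 to compound 4 (0.07 log units; that floor lies within the scatter), an at least 1.1-fold lower number from compound 1 to compound 4 (0.07 log units; that floor lies within the scatter), and a 1.2-fold lower number from compound 2 to compound 4 (0.07 log units; within the scatter). The chloro group thus adds a second exact value to that of compound 2, and the two lie within the scatter of each other. Only that step has a full size, while the other two are floors set by a limit: the limit of > 100000 nM in this assay, at which 2 of the 4 values shown sit.

The compounds shown leave open how this assay responds to an amine or a carboxylic acid on this phenyl ring. They also leave open whether any group at this position moves the value beyond the scatter.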